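A methyl to ethyl step from compound 2

The source may hold more compounds than are shown below. What is called first, only, known or untested is meant among the compounds shown, and "the series" means these compounds.

In a functional assay on MCF7 cells (Homo sapiens) for cytotoxicity, read by MTT assay, with a stated time of 48 h (a lower number here means a stronger inhibitor, a higher number a weaker inhibitor), compound 1 (`CCn1c(/C=C2/C(=O)Nc3ccccc32)nc2ccccc21`) stands as "not determined" (no result reported) with no number to go on. Compound 2 (`Cn1c(/C=C2/C(=O)Nc3ccc(Cl)cc32)nc2ccccc21`) gives only a limit of > 50000 nM and no exact number. Compound 3 (`CCn1c(/C=C2/C(=O)Nc3ccc(Cl)cc32)nc2ccccc21`) differs from compound 2 by methyl in place of hydrogen on a saturated chain carbon bound to an aromatic nitrogen (methyl in place of hydrogen on a saturated chain carbon bound to an aromatic nitrogen, so methyl to ethyl). Among the compounds with values here, no measured pair shows this change, so a shift no larger than the usual scatter, in no set direction, is expected in this assay here. The estimated step of a number no higher from compound 2 to compound 3 (the limit leaves the size open) is accordingly small. Compound 3 is expected at 50000 nM with an estimated range of 15000 nM to 100000 nM in all.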

Compound 3, half-maximal inhibitory concentration: > 50000 nM
Compound 3 gave a limit, no number; the forecaster's own chance of this, stated with the estimate: 60%; the middle value lies on the limit itself.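

Within the data shown here, compound 2 and compound 3 both give only limits in this assay, so no step between them can be read. From the compounds shown here alone, whether the methyl to ethyl change shifts this read-out at all remains open.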